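A few compounds are considered here, and "the series" means these few. Any claim that something is new, unique, unknown or untested is made for them only; others in the source may bear on it.

Working notes on the series. In a functional assay on MCF7 cells (Homo sapiens) for antiproliferative activity, read by MTT assay, with a stated time of 48 h (on this read-out lower numbers stand for stronger inhibition and higher numbers for weaker inhibition), compound 1 (`COc1cccc(-c2nc3cccc(-c4cc(OC)c(OC)c(OC)c4)c3o2)c1`) gives > 25000 nM as a limit of the assay and not a number. Compound 2 (`COc1cc(-c2cccc3nc(-c4cccc(F)c4)oc23)cc(OC)c1OC`) gives > 25000 nM and this too is a limit. Going by the values given here, compound 2 therefore has no number to start from, and the one other value beside it is also a limit (the limit of > 25000 nM in this assay, at which 2 of the 2 values shown sit).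

Compound 3 (`COc1cc(-c2cccc3nc(-c4cccc(Br)c4)oc23)cc(OC)c1OC`) differs from compound 2 by a single exchange (bromo in place of fluoro on an aromatic carbon) with bromo in place of fluoro on an aromatic carbon, meta to a large group. Among the compounds with values here, the one measured step that bears on it is a step that the two limits leave unreadable from compound 1 to compound 2 with fluoro in place of methoxy on an aromatic carbon, and it offers no size to carry over. No step beyond the scatter can be forecast in either direction in this assay and compound 3 is expected to remain close to the limit, quite possibly reported as a limit itself. The estimated step is a number no higher from compound 2 to compound 3 (the limit leaves the size open) and it remains an expectation only. For compound 3 the estimated value is 25000 nM with an expected range from 8000 nM to 40000 nM in this read-out.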

Compound 3, half-maximal inhibitory concentration: > 25000 nM
Compound 3 was reported as a limit; the forecaster's own chance of this, stated with the estimate: 70%; the middle value sits exactly at the limit.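

In this assay compound 3 gives > 25000 nM, a limit of the assay and not a number. The steps among compound 1, compound 2 and compound 3 therefore cannot be read: the limit of > 25000 nM in this assay, at which 3 of the 3 values shown sit. The compounds shown leave open how far these three differ from one another and whether any exchange at this place gives a measurable value in this assay.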